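Amide-side aryl exchange in a reductase inhibitor series

The compounds below may be only part of what the source reports. "The series", "measured", "known", "first", "only" and "open" are said of these compounds alone.

Measured compounds:
compound 1 `CC(C)c1c(C(=O)N2CCC[C@H](c3ccccc3)C2)nn(-c2ccc(F)cc2)c1OC[C@@H](O)C[C@@H](O)CC(=O)O`: 4.8 nM in an assay on microsomes from liver for inhibition of 3-hydroxy-3-methylglutaryl-coenzyme A reductase (Rattus norvegicus); on this read-out higher numbers stand for weaker inhibition and lower numbers for stronger inhibition
compound 2 `COc1ccc(CNC(=O)c2nn(-c3ccc(F)cc3)c(OC[C@@H](O)C[C@@H](O)CC(=O)O)c2C(C)C)cc1`: 12 nM in this assay

Going by the values given here, compound 2 holds the highest of the two numbers; its nearest neighbour is compound 1, and the only single-point step measured so far, a 2.5-fold higher number from compound 1 to compound 2 (0.40 log units; beyond the scatter), is a modest rise in the number on exchanging the amine part of the amide.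

Compound 3 `CC(C)c1c(C(=O)NCc2ccccn2)nn(-c2ccc(F)cc2)c1OC[C@@H](O)C[C@@H](O)CC(=O)O` differs from compound 2 by pyridin-2-yl in place of 4-methoxyphenyl on a saturated chain carbon bound to an amide-type nitrogen. Among the compounds with values here, no measured step touches this ring exchange directly; the one step in hand alters the whole amine and is itself only modest. With nothing pointing to a large shift, the change a 1.3-fold higher number from compound 2 to compound 3 (0.10 log units; within the scatter) is expected to stay near the scatter, if anything a slight rise. Compound 3 is therefore expected at about 15 nM, with a range from 6 nM to 40 nM.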

Compound 3, half-maximal inhibitory concentration: 25 nM
Compound 3: middle estimate off by 1.7-fold (0.22 log units), on the low side; measured number inside the range.
By their numbers in this assay, from the lowest: compound 1; then compound 2; then compound 3.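

In this assay, the aromatic ring on the saturated chain carbon bound to the amide-type nitrogen affects the read-out on its own, whereas the earlier step exchanged the whole amine: with pyridin-2-yl in place of 4-methoxyphenyl, the step is a 2.1-fold higher number from compound 2 to compound 3 (0.32 log units; beyond the scatter). Set against the 3-phenylpiperidin-1-yl amide, the ((pyridin-2-yl)methyl)amino group gives a 5.2-fold higher number from compound 1 to compound 3 (0.72 log units; beyond the scatter), and compound 3 holds the highest number of the three. No measurement in hand accounts for either rise.

From the compounds shown here alone, the methoxy group and the ring nitrogen change together in this exchange, and the share of each in the step remains open. A plain phenyl ring or pyridin-4-yl on the same chain carbon would divide the two contributions.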